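The compounds below may be only part of what the source reports. "The series", "measured", "known", "first", "only" and "open" are said of these compounds alone.

Three amides built on one shared core have been measured in a functional assay on MCF7 cells (Homo sapiens) for inhibition, read by MTT assay (a higher number here means a weaker inhibitor, a lower number a stronger inhibitor), so far. In this assay compound 1 `COc1cc2ncnc(Nc3ccc(NC(=O)c4cccc(C)c4)cc3)c2cc1OC` gives 13000 nM and is the strongest of the three. Compound 2 `CCc1ccc(C(=O)Nc2ccc(Nc3ncnc4cc(OC)c(OC)cc34)cc2)cc1` gives 65000 nM and compound 3 `COc1cc2ncnc(Nc3ccc(NC(=O)c4ccc(Br)cc4)cc3)c2cc1OC` gives 43000 nM in the same test. Compound 3 therefore sits with compound 2 at the weak end of the set. The gap between those two is a 1.5-fold lower number from compound 2 to compound 3 (0.18 log units; within the scatter) and lies within the scatter, while the gap to the strongest compound is a 3.3-fold higher number from compound 1 to compound 3 (0.52 log units; beyond the scatter) and is modest.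

Compound 4 `COc1cc2ncnc(Nc3ccc(NC(=O)c4ccc(I)cc4)cc3)c2cc1OC` changes only the halogen of compound 3: iodo in place of bromo on an aromatic carbon puts iodo in place of bromo on an aromatic carbon, para to a large group. The closest guide is the exchange at this same place, where a 1.5-fold lower number from compound 2 to compound 3 (0.18 log units; within the scatter) stayed within the scatter. The larger step of a 5.0-fold higher number from compound 1 to compound 2 (0.70 log units; beyond the scatter) and the step of a 3.3-fold higher number from compound 1 to compound 3 (0.52 log units; beyond the scatter) replace the whole aryl group, so they bear on this exchange less directly. Going by the values given here, no iodo compound has a measured value yet.

The expected size of the change is a 1.1-fold lower number from compound 3 to compound 4 (0.03 log units; within the scatter) and no move beyond the scatter is anticipated. Compound 4 is estimated at 40000 nM in this assay with an expected range from 18000 nM to 85000 nM for its measurement.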

Compound 4, half-maximal inhibitory concentration: 48000 nM
Beside the measured number, compound 4's estimate is 1.2-fold (0.08 log units) below it; low and high end bracket the measured number.
By their numbers in this assay, from the lowest: compound 1; then compounds 3, 4 and 2 (each within the scatter of the next).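

In this assay the halogen at this place can be enlarged from bromo to iodo, on an aromatic carbon para to a large group, with no change beyond the scatter (a 1.1-fold higher number from compound 3 to compound 4 (0.05 log units; within the scatter)), and iodo also reads the same as ethyl at this carbon (a 1.4-fold lower number from compound 2 to compound 4 (0.13 log units; within the scatter)). Going by these compounds alone, compounds 2, 3 and 4, the 4-ethylphenyl, 4-bromophenyl and 4-iodophenyl amides, now form one cluster of three, with no compound among them going against it, while the 3-methylphenyl amide compound 1 remains apart by a modest step beyond the scatter (a 3.7-fold higher number from compound 1 to compound 4 (0.57 log units; beyond the scatter)). Nothing shown here accounts for this flat reading across the three groups or for the separation of compound 1.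

The compounds shown leave open whether this flat reading extends to groups of a different kind at the same carbon, such as an amine, a carboxylic acid or a longer alkyl chain. They also leave open what sets compound 1 apart, since it differs from the others in both the group and its place on the ring, and only a 4-methylphenyl or a 3-bromophenyl amide would separate those two changes.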